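Replacing the Nitro Group in a Dienone Series

This account rests on a few compounds, and the source may have more. Where it says the series, first, only, none or still open, it means among the compounds named here.

Compound 2 `O=C(/C=C/c1cc([N+](=O)[O-])ccc1Cl)/C=C/c1ccccc1Oc1ncnc2ccc(Cl)cc12` is measured in a functional assay on PC-3 cells (Homo sapiens) for inhibition, read by MTT assay, with a stated time of 72 h (a lower number here means a stronger inhibitor, a higher number a weaker inhibitor), at 2510 nM. Compound 1 `O=C(/C=C/c1ccc(Oc2ncnc3ccc(Cl)cc23)cc1)/C=C/c1cc([N+](=O)[O-])ccc1Cl` gives 3150 nM in this assay, a number within the scatter of compound 2, while compound 3 `O=C(/C=C/c1ccc(Oc2ncnc3ccc(Cl)cc23)cc1)/C=C/c1ccc(Cl)c(Cl)c1` gives 18800 nM. Within the data shown here, the only single-point step recorded is a 6.0-fold higher number from compound 1 to compound 3 (0.78 log units; beyond the scatter). Compound 4 `O=C(/C=C/c1ccccc1Oc1ncnc2ccc(Cl)cc12)/C=C/c1c(Cl)cccc1Cl` differs from compound 2 in 2,6-dichlorophenyl in place of 2-chloro-5-nitrophenyl on a double-bonded chain carbon bound to a double-bonded chain carbon. That change, like the step from compound 1 to compound 3, removes the 2-chloro-5-nitrophenyl group in favour of a dichlorophenyl group, though with a different arrangement of the two chlorines, so a weakening of similar size is expected. Compound 4 is therefore estimated at 10000 nM in this assay, with a likely range of 3500 nM to 30000 nM. That estimate corresponds to an expected 4.0-fold higher number from compound 2 to compound 4 (0.60 log units; beyond the scatter).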

Compound 4, half-maximal inhibitory concentration: 7980 nM
Compound 4: middle estimate off by 1.3-fold (0.10 log units), on the high side; low and high end bracket the measured number.
By their numbers in this assay, from the lowest: compounds 2 and 1 (each within the scatter of the next); then compound 4; then compound 3.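

Putting 2,6-dichlorophenyl in place of 2-chloro-5-nitrophenyl gives a 3.2-fold higher number from compound 2 to compound 4 (0.50 log units; beyond the scatter) in this assay. The rise seen earlier with compound 3 therefore recurs with a different arrangement of the two chlorines and from a different parent, compound 2 rather than compound 1. No available evidence bears on the reason for this rise.

The compounds shown leave open whether a phenyl group carrying an amine or a carboxylic acid in place of the nitro group would keep the number near that of compound 2.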